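Compound 1 to compound 4: replacing the tert-butyl

This account rests on a few compounds, and the source may have more. Where it says the series, first, only, none or still open, it means among the compounds named here.

In an ADME assay on Caco-2 cells (Homo sapiens) for permeability, read by LC-MS, in the apical to basolateral direction, with a stated time of 60 min, at pH 6.5 (a lower number here means that the compound crosses the layer more slowly, a higher number that the compound crosses the layer faster), compound 1 (`CC(C)(C)[C@@H](O)C(=O)N1C[C@@H]2C[C@@H]2[C@H]1C(=O)NCc1cc(Cl)ccc1-n1cnnn1`) gives 17 10^-6 cm/s, the highest of the three numbers available. Compound 2 (`CC(C)(C)[C@@H](O)C(=O)N1C[C@H]2C[C@H]2[C@H]1C(=O)NCc1cc(Cl)ccc1-n1cnnn1`) gives 3.8 10^-6 cm/s, and compound 3 (`O=C(NCc1cc(Cl)ccc1-n1cnnn1)[C@@H]1[C@@H]2C[C@@H]2CN1C(=O)[C@H](O)c1ccccc1F`) gives 2.3 10^-6 cm/s. Compound 4 (`O=C(NCc1cc(Cl)ccc1-n1cnnn1)[C@@H]1[C@H]2C[C@H]2CN1C(=O)[C@H](O)Cn1cccn1`) is still unmeasured. It differs from compound 1 as follows: (1H-pyrazol-1-yl)methyl in place of tert-butyl on a saturated chain carbon bound to a carbonyl carbon and an oxygen on a saturated carbon. The configuration of compound 1 is kept, so the step of a 4.5-fold lower number from compound 1 to compound 2 (0.65 log units; beyond the scatter) offers no direct guide, because of the fact that compounds 1 and 2 differ only in the configuration as drawn. For the measured compounds named here, the nearest precedent is the step of a 1.7-fold lower number from compound 2 to compound 3 (0.22 log units; within the scatter), where 2-fluorophenyl replaces the same tert-butyl. That is a different entering group on the other configuration, so it is only a weak guide. It points to a lower number in this assay, and a modest step is expected rather than a large one. The expected step is a 2.4-fold lower number from compound 1 to compound 4 (0.39 log units; beyond the scatter). For compound 4 the estimate is 7 10^-6 cm/s, with an expected range of 2.5 10^-6 cm/s to 17 10^-6 cm/s.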

Compound 4, apparent permeability: 0.31 10^-6 cm/s
Estimate against measurement, compound 4: 23-fold (1.35 log units) above, and the stated range ends above it.
By their numbers in this assay, from the lowest: compound 4; then compounds 3 and 2 (each within the scatter of the next); then compound 1.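

In this assay, the position on the saturated chain carbon bound to a carbonyl carbon and an oxygen on a saturated carbon proves able to carry a large change: (1H-pyrazol-1-yl)methyl in place of tert-butyl gives a 55-fold lower number from compound 1 to compound 4 (1.74 log units; beyond the scatter). Loss of tert-butyl alone therefore does not set the outcome, since 2-fluorophenyl on the other configuration gave only a 1.7-fold lower number from compound 2 to compound 3 (0.22 log units; within the scatter), and the entering group matters at this position. The data at hand give no cause for the size of the new step.

Open, going by these compounds, is whether a benzyl group, with a carbon-only ring in place of the pyrazole, would give a step of similar size. Also open, on these data alone, is whether (1H-pyrazol-1-yl)methyl would give such a step on the configuration of compound 2.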